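The source may hold more compounds than are shown below. What is called first, only, known or untested is meant among the compounds shown, and "the series" means these compounds.

In an ADME assay for permeability, using PAMPA, with a stated time of 30 min, at pH 7.4 (a lower number here means that the compound crosses the layer more slowly, a higher number that the compound crosses the layer faster), compound 2 (`COc1ccc(-c2c(-c3ccc(OC)cc3)n(Cc3ccccc3)c3ncn([C@H]4CC[C@H](O)CC4)c(=N)c23)cc1`) gives 196 10^-6 cm/s. Among the compounds with values here, this is the only number in the set: compound 1 (`COc1ccc(Cn2c(-c3ccccc3)c(-c3ccccc3)c3c(=N)n(C4CCOCC4)cnc32)cc1`) has no result in this assay, recorded as "nd" (no result reported), so compound 2 stands alone and nothing can be ranked around it.

Compound 3 (`COc1ccc(-c2c(-c3ccc(OC)cc3)n(Cc3ccccc3)c3ncn([C@@H]4CCCC[C@H]4O)c(=N)c23)cc1`) shares everything with compound 2 apart from one change: 2-hydroxycyclohexyl in place of 4-hydroxycyclohexyl on an aromatic nitrogen. The same atoms are present in both, only joined differently, with the hydroxyl moved along the saturated ring. Within the data shown here, no measured pair in this set shows what such a rearrangement does, so the step can only be estimated from the structures themselves. With the same count of heavy atoms, donors and acceptors, the step in this assay from compound 2 to compound 3 is expected to be small, a 1.1-fold lower number from compound 2 to compound 3 (0.04 log units; within the scatter), and not beyond the scatter of repeated measurements in either direction.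

Compound 3 is therefore estimated to give about 180 10^-6 cm/s, with a likely range from 80 10^-6 cm/s to 350 10^-6 cm/s.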

Compound 3, apparent permeability: > 1000 10^-6 cm/s
Compound 3: only a limit was reported; the forecaster's own chance of this, stated with the estimate: 5%; middle value at least 5.5-fold (0.74 log units) away from the limit.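

Until now this position had a single number behind it, from compound 2 alone, so nothing showed whether the group on the aromatic nitrogen mattered in this assay. It does matter, even though the atoms stay the same and only the hydroxyl's place on the saturated ring differs: 2-hydroxycyclohexyl in place of 4-hydroxycyclohexyl gives an at least 5.1-fold higher number from compound 2 to compound 3 (0.70 log units; beyond the scatter). The reading of compound 3 is a limit of the assay and not a number, so this step can be taken only as a minimum, because it rests on this one reading: the limit of > 1000 10^-6 cm/s in this assay, at which 1 of the 3 values shown sits.

Going by these compounds, the compounds with a number carry only a hydroxyl on the saturated ring, in two places, so it remains open whether an amine or a carboxylic acid at either place would give a similar reading in this assay. Also open, on these data alone, is whether the 2-hydroxycyclohexyl group with its two stereocentres arranged the other way would read like compound 3, and how far compound 3 truly lies from compound 2.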